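Anilide series: cyclopentyl to 1-fluoroethyl on the amide carbonyl

This account rests on a few compounds, and the source may have more. Where it says the series, first, only, none or still open, it means among the compounds named here.

Compound 3 `COc1ccc(C(=O)Nc2ccccc2)cc1NC(=O)C1CCCC1` stands highest of the three compounds measured in an ADME assay on MDCK cells (Canis lupus familiaris) for cytotoxicity, read by cytopathic effect, with a stated time of 48 h; on this read-out lower numbers stand for higher toxicity in this test and higher numbers for lower toxicity in this test: compound 3 gives 459 uM. Compound 1 `COc1ccc(C(=O)Nc2ccccc2)cc1NC(=O)C(C)Cl` gives 200 uM and compound 2 `COc1ccc(C(=O)Nc2ccccc2)cc1NC(=O)c1ccccc1` gives 193 uM; the step of a 1.0-fold lower number from compound 1 to compound 2 (0.02 log units; within the scatter) lies within the scatter, while a 2.3-fold higher number from compound 1 to compound 3 (0.36 log units; beyond the scatter) and a 2.4-fold higher number from compound 2 to compound 3 (0.38 log units; beyond the scatter) are both modest and beyond it. The next compound, compound 4 `COc1ccc(C(=O)Nc2ccccc2)cc1NC(=O)C(C)F`, differs from compound 3 by 1-fluoroethyl in place of cyclopentyl on a carbonyl carbon. The step that bears on this is a 2.3-fold higher number from compound 1 to compound 3 (0.36 log units; beyond the scatter) read in reverse: compound 1 carries a 1-chloroethyl group on a carbonyl carbon, compound 4 a 1-fluoroethyl group; compound 2 carries phenyl there and is further removed. A modest downward step in this assay is therefore expected, a 2.2-fold lower number from compound 3 to compound 4 (0.34 log units; beyond the scatter). The estimate for compound 4 is 210 uM, with a range from 100 uM to 450 uM.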

Compound 4, half-maximal toxic concentration: > 632 uM
Compound 4 ended at the assay's limit; the forecaster's own chance of this, stated with the estimate: 10%; middle value at least 3.0-fold (0.47 log units) away from the limit.
By their numbers in this assay, from the lowest: compounds 2 and 1 (each within the scatter of the next); then compound 3. At a limit, above all of these: compound 4.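

In this assay compound 4 stands at a limit, not at a number: the limit of > 632 uM in this assay, at which 1 of the 4 values shown sits. Exchanging only the halogen at this position is a clear change, with fluoro in place of chloro giving an at least 3.1-fold higher number from compound 1 to compound 4 (0.49 log units; beyond the scatter), and the replacement of phenyl gives an at least 3.2-fold higher number from compound 2 to compound 4 (0.51 log units; beyond the scatter). Against cyclopentyl the result is less decisive: an at least 1.3-fold higher number from compound 3 to compound 4 (0.13 log units; that floor lies within the scatter), so this floor alone does not separate 1-fluoroethyl from cyclopentyl. As far as these compounds go, how far compound 4 lies past the limit remains open, as does the reading for an unsubstituted ethyl group or a 1-aminoethyl group on the same carbonyl carbon.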